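From carboxy to ethoxycarbonyl: a forecast for compound 3

The source may report more compounds than this note shows. Statements on the series, on what has been measured and on what is new or still open speak of the compounds shown alone.

Measured in a functional assay on MCF7 cells (Homo sapiens) for inhibition, read by MTT assay, with a stated time of 3 days; on this read-out higher numbers stand for weaker inhibition and lower numbers for stronger inhibition:
Compound 1 `COc1cc(-c2nc3ccccc3s2)ccc1OCC(=O)NNC(=O)CNC(=N)NCCC[C@H](N[N+](=O)[O-])C(=O)O`: 1960 nM
Compound 2 `COc1cc(-c2nc3ccccc3s2)ccc1OCC(=O)NNC(=O)CN1CCC[C@H]1C(=O)O`: 840 nM

Compound 2 has the lower of the two numbers, and its gap to compound 1 lies beyond the usual scatter of repeats. Compound 3 `CCOC(=O)[C@@H]1CCCN1CC(=O)NNC(=O)COc1ccc(-c2nc3ccccc3s2)cc1OC` differs from compound 2 at one place: ethyl in place of hydrogen on an oxygen next to a carbonyl group, which turns carboxy into ethoxycarbonyl. Within the data shown here, no measured pair shows this exchange, so any forecast is loose. In this assay, a modest shift toward a lower number is expected, about the size of the scatter. The expected change is a 1.5-fold lower number from compound 2 to compound 3 (0.18 log units; within the scatter). For compound 3 the estimated value is 550 nM, with an estimated range of 180 nM to 1700 nM.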

Compound 3, half-maximal inhibitory concentration: 770 nM
The estimate for compound 3 lay 1.4-fold (0.15 log units) below the measured number, and the stated range covers the measured number.
By their numbers in this assay, from the lowest: compounds 3 and 2 (each within the scatter of the next); then compound 1.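

In this assay, the step is a 1.1-fold lower number from compound 2 to compound 3 (0.04 log units; within the scatter) when ethyl takes the place of hydrogen on an oxygen next to a carbonyl group. At this position, then, carboxy and ethoxycarbonyl cannot be told apart on this read-out, so the hydrogen can give way to ethyl without a step beyond the scatter. No measurement offered here accounts for this result. Open questions are whether a longer chain such as butyl or a bulkier benzyl on the same oxygen would also leave the number within the scatter, and how a primary amide in place of ethoxycarbonyl would read.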